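Chloro on the phenyl ring of two aryl pyrazole cores

The compounds below may be only part of what the source reports. "The series", "measured", "known", "first", "only" and "open" are said of these compounds alone.

Compound 2 `c1ccc(-c2n[nH]cc2N2CCCNCC2)cc1` and compound 1 `Clc1ccc(-c2n[nH]cc2N2CCCNCC2)cc1` share one core; compound 3 `c1ccc(-c2n[nH]cc2N2CCNCC2)cc1` carries another, and the difference between the two cores is not broken down here. In an assay on isolated protein for binding affinity to 5-hydroxytryptamine receptor 1E (Homo sapiens) (on this read-out lower numbers stand for stronger inhibition and higher numbers for weaker inhibition), compound 2 gives only a limit, > 10000 nM. Compound 1 likewise gives only a limit in this assay, > 10000 nM. Compound 3 also gives only a limit in this assay, > 10000 nM. The change chloro in place of hydrogen on an aromatic carbon thus yields a step that the two limits leave unreadable from compound 2 to compound 1, and nothing further can be read, due to the limit of > 10000 nM in this assay, at which 3 of the 3 values shown sit. Compound 4 `Clc1ccccc1-c1n[nH]cc1N1CCNCC1` is not yet measured; it arises from compound 3 by chloro in place of hydrogen on an aromatic carbon, the same kind of change but not the same, the place being ortho to a large group rather than para to a large group. The expected step that the limit leaves unreadable from compound 3 to compound 4 rests only on the shared limit. Compound 4 is therefore estimated at 30000 nM, most likely again reported as a limit.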

Compound 4, inhibition constant: > 10000 nM
Compound 4 was reported as a limit (the forecaster's own chance of this, stated with the estimate: 80%); the middle value lies beyond the limit too.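

No new step can be read between compound 3 and compound 4 in this assay, due to one shared limit: the limit of > 10000 nM in this assay, at which 4 of the 4 values shown sit.

The compounds shown leave open what chloro in place of hydrogen does on either core.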